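Chloro to Bromo on a Spirocyclic Series in HeLa Cells

The compounds below may be only part of what the source reports. "The series", "measured", "known", "first", "only" and "open" are said of these compounds alone.

Compound 1, `O=C1c2cccc([N+](=O)[O-])c2NC[C@@]12[C@H](c1ccc(Br)cc1)[C@@H](c1ccccc1)N[C@]21C(=O)Nc2ccc(Cl)cc21`: 21000 nM
Compound 2, `O=C1c2cccc([N+](=O)[O-])c2NC[C@@]12[C@H](c1ccc(Cl)cc1)[C@@H](c1ccccc1)N[C@]21C(=O)Nc2ccc(F)cc21`: 25000 nM

Of the compounds shown here, two have been tested in a functional assay on HeLa cells (Homo sapiens) for cytotoxicity, read by MTT assay, with a stated time of 72 h; a lower number here means a stronger inhibitor, a higher number a weaker inhibitor. Compound 1 gives 21000 nM there, and compound 2 gives 25000 nM. Compound 2 holds the highest of the two numbers, but its nearest neighbour, compound 1, lies within the usual scatter of such measurements, so the two cannot be told apart in this assay.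

Compound 3, `O=C1c2cccc([N+](=O)[O-])c2NC[C@@]12[C@H](c1ccc(Br)cc1)[C@@H](c1ccccc1)N[C@]21C(=O)Nc2ccc(F)cc21`, has not yet been tested. It differs from compound 2 in one spot only: bromo in place of chloro on an aromatic carbon. For the measured compounds named here, no pair of measured compounds separated by a single change is available, so there is no direct precedent for the size of this particular step. Both measured compounds already sit close together despite carrying different halogens, which suggests that swapping one halogen for another at this spot is unlikely to move the number far. The step from compound 2 to compound 3 is therefore expected to stay within the scatter, a 1.1-fold lower number from compound 2 to compound 3 (0.06 log units; within the scatter). Compound 3 is estimated at 22000 nM in this assay, within a range of 10000 nM to 48000 nM.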

Compound 3, half-maximal inhibitory concentration: 26000 nM
Compound 3: middle estimate off by 1.2-fold (0.07 log units), on the low side, and the stated range covers the measured number.
By their numbers in this assay, from the lowest: compounds 1, 2 and 3 (each within the scatter of the next).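

Read in this assay the swap from 4-chlorophenyl to 4-bromophenyl now has a direct measurement, a 1.0-fold higher number from compound 2 to compound 3 (0.02 log units; within the scatter) and so chloro and bromo cannot be told apart at this spot, para to a large group on a six-membered aromatic ring of carbon only. Compound 3 also links compound 1 through a single change elsewhere on the shared core, with a fluorine atom taking the place of a chlorine atom, and a 1.2-fold higher number from compound 1 to compound 3 (0.09 log units; within the scatter) shows that these two halogens cannot be told apart there either. Nothing among the available data bears on why these halogen swaps leave the compounds indistinguishable in this test.

The compounds shown carry only halogens at these two spots, so what a methoxy group, an amine or a carboxylic acid would do there remains open. On these data alone, all three compounds also share the nitro group and the unsubstituted phenyl ring, so the contribution of those parts to the cytotoxicity remains open as well.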